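Branching a Side Chain on a Bombesin Receptor Agonist

The source may hold more compounds than are shown below. What is called first, only, known or untested is meant among the compounds shown, and "the series" means these compounds.

Compound 1 `O=C(O)c1ccccc1-c1ccc(CCc2ncc(Cc3ccccc3F)[nH]2)cc1`: 9.5 nM
Compound 2 `CCCCc1cnc(C(CC)Cc2ccc(-c3ccccc3C(=O)O)cc2)[nH]1`: 340 nM

In an in vitro functional assay on cells for agonist activity at Bombesin receptor subtype-3 (Mus musculus), read by luminescence and calcium flux (on this read-out higher numbers stand for an effect only at larger amounts of compound and lower numbers for an effect already at smaller amounts), compound 2 gives the highest of the two numbers shown, with compound 1 at a far lower number, beyond the scatter. Compound 3 `CCCCc1cnc(C(Cc2ccc(-c3ccccc3C(=O)O)cc2)C(C)C)[nH]1` differs from compound 2 in one place: methyl in place of hydrogen on a saturated chain carbon bound to two saturated chain carbons. Going by the values given here, no measured pair shows what this kind of change does in this assay, so only the structures speak. A small step from compound 2 to compound 3 is expected, likely within the scatter, and it is estimated as a 1.1-fold lower number from compound 2 to compound 3 (0.05 log units; within the scatter). Compound 3 is therefore expected to give about 300 nM, within 100 nM to 1000 nM.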

Compound 3, half-maximal effective concentration: 2240 nM
Compound 3: the middle estimate sits 7.5-fold (0.87 log units) below what was measured; the measured number lies above the stated range.
By their numbers in this assay, from the lowest: compound 1; then compound 2; then compound 3.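

In this assay, one added methyl, which turns ethyl into isopropyl on a saturated chain carbon bound to two saturated chain carbons, gives a 6.6-fold higher number from compound 2 to compound 3 (0.82 log units; beyond the scatter). This carbon is therefore sensitive to a single extra carbon atom, and the more branched compound 3 needs more compound for the same effect. Nothing measured here gives the reason for this step. Going by these compounds, what remains open is how a cyclopropyl group or a plain methyl on this carbon would compare with compound 2. A hydroxyl group there is equally unresolved.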